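This account rests on a few compounds, and the source may have more. Where it says the series, first, only, none or still open, it means among the compounds named here.

The measured compounds:
compound 1 `Clc1cccc(CSc2nnc(-c3ccncc3)n2-c2ccccc2)c1`, in a functional assay on HCT-116 cells (Homo sapiens) for inhibition, read by MTT assay, with a stated time of 48 h (on this read-out higher numbers stand for weaker inhibition and lower numbers for stronger inhibition), 9820 nM
compound 2 `O=[N+]([O-])c1cccc(CSc2nnc(-c3ccncc3)n2-c2ccccc2)c1`, in this assay 19800 nM
compound 3 `O=C(CSc1nnc(-c2ccncc2)n1-c1ccccc1)N/N=C/c1ccc(Cl)cc1`, in this assay 5740 nM

Compound 3 gives the lowest of the three numbers in this assay. Its number and that of compound 1 lie within the scatter of each other, so no order between them can be claimed, whereas compound 2 sits beyond the scatter above compound 3. Compound 4 `O=C(CSc1nnc(-c2ccncc2)n1-c1ccccc1)N/N=C/c1ccc(O)c(O)c1` is the next compound, with one change from compound 3: 3,4-dihydroxyphenyl in place of 4-chlorophenyl on a carbon with a double bond to nitrogen. Among the compounds with values here, the only measured step is a 2.0-fold higher number from compound 1 to compound 2 (0.30 log units; within the scatter), which concerns the benzyl thioether of compounds 1 and 2, not the hydrazone aryl group that is changed here, and it stayed within the scatter. Within the data shown here, no measured pair touches the group that is exchanged between compound 3 and compound 4, so the direction of the change is unknown. Compound 4 is therefore expected to give a number close to that of compound 3, with a step of a 1.1-fold lower number from compound 3 to compound 4 (0.06 log units; within the scatter), meaning no step beyond the scatter. The estimate for compound 4 in this assay is 5000 nM, with a range from 1500 nM to 16000 nM.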

Compound 4, half-maximal inhibitory concentration: 14700 nM
Compound 4: middle estimate off by 2.9-fold (0.47 log units), on the low side, and the stated range covers the measured number.
By their numbers in this assay, from the lowest: compounds 3, 1, 4 and 2 (each within the scatter of the next, the first and the last beyond it).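

Within the data shown here, the aryl group on a carbon with a double bond to nitrogen is not silent in this assay: 3,4-dihydroxyphenyl in place of 4-chlorophenyl gives a 2.6-fold higher number from compound 3 to compound 4 (0.41 log units; beyond the scatter), whereas the only earlier step, a 2.0-fold higher number from compound 1 to compound 2 (0.30 log units; within the scatter), concerned a different place and stayed within the scatter. This exchange therefore goes with weaker inhibition, although that direction rests on this single pair. Nothing given here accounts for the size or direction of the step.

The compounds shown leave open whether the weaker inhibition follows the arrival of the hydroxyl groups or the departure of the chloro group; a plain phenyl or a 4-hydroxyphenyl at this place would separate the two. They also leave open how an amine or a carboxylic acid on this ring would read.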